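Carboxy to carbamoyl on the thiazole core: expected growth inhibition

The source may report more compounds than this note shows. Statements on the series, on what has been measured and on what is new or still open speak of the compounds shown alone.

Measured compounds:
- compound 1, `CN1CCN(c2ccc(Nc3nc(-c4cccc(NC(=O)c5ccccc5)c4)sc3C(=O)O)cc2)CC1`: 11.9%
- compound 2, `CN1CCN(c2ccc(Nc3nc(-c4cccc(NC(=O)c5ccc(Cl)cc5)c4)sc3C(=O)O)cc2)CC1`: 90.9%
- compound 3, `CN1CCN(c2ccc(Nc3nc(-c4cccc(NC(=O)c5ccc(F)c(Cl)c5)c4)sc3C(=O)O)cc2)CC1`: 87.9%

All three were tested in a functional assay on Raji cells (Homo sapiens) for antiproliferative activity, read by CCK-8 assay, with a stated time of 72 h, tested at 40 uM; on this read-out higher numbers stand for more inhibition at the one concentration tested (going by the name of the read-out) and lower numbers for less inhibition. Compound 3 stands second highest of the three numbers, and its nearest neighbour is compound 2, because a number 3 percentage points lower from compound 2 to compound 3 (within the scatter). The only large movements in this small set came from changing the benzamide ring: a number 79 percentage points higher from compound 1 to compound 2 (beyond the scatter) and a number 76 percentage points higher from compound 1 to compound 3 (beyond the scatter).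

Compound 4, `CN1CCN(c2ccc(Nc3nc(-c4cccc(NC(=O)c5ccc(F)c(Cl)c5)c4)sc3C(N)=O)cc2)CC1`, keeps the benzamide of compound 3 unchanged and differs only at the carbonyl carbon on the shared core: amino in place of hydroxy on a carbonyl carbon. Within the data shown here, none of the measured steps touches this part of the molecule, so the steps above do not bear on it directly; they only show that compound 3 starts from a high level of inhibition. With no guide for this change, the step of a number 12.9 percentage points lower from compound 3 to compound 4 (beyond the scatter) is expected to be modest, with a wide range to either side. Compound 4 is therefore estimated to give 75% in this assay, between 35% and 95%.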

Compound 4, a percentage reported as inhibition, at one concentration (the size of the read-out at that concentration, not a potency): 94.4%
The estimate for compound 4 lay 19.4 percentage points below the measured number, within the range that was stated.
By their numbers in this assay, from the lowest: compound 1; then compounds 3, 2 and 4 (each within the scatter of the next).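

In this assay, amino in place of hydroxy on the carbonyl carbon gives a number 6.5 percentage points higher from compound 3 to compound 4 (within the scatter) and so does not separate the two compounds. With this benzamide, then, the carboxy group on the shared core is not needed for high inhibition at the one concentration tested, since the carbamoyl group of compound 4 serves equally well on this read-out. The data offer no explanation for this match between the two groups.
Still open, from the compounds shown here alone, is whether a methyl ester or a methylamide at the same place would also keep this level of inhibition. Going by these compounds, a single concentration could also hide a difference in potency between compound 3 and compound 4, and the carbamoyl group remains unknown on the unsubstituted benzamide of compound 1.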